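Notes on the step from compound 2 to compound 4

The source may report more compounds than this note shows. Statements on the series, on what has been measured and on what is new or still open speak of the compounds shown alone.

compound 1 `CC(=O)N1CCN(C(=O)N2Cc3c(NC(=O)c4ccc(F)cc4)n[nH]c3C2(C)C)CC1`: > 10000 nM
compound 2 `CN1CCC(C(=O)N2Cc3c(NC(=O)c4ccsc4)n[nH]c3C2(C)C)CC1`: 140 nM
compound 3 `CCN1CCC(C(=O)N2Cc3c(NC(=O)CC(C)C)n[nH]c3C2(C)C)CC1`: 410 nM

All three values come from a functional assay on A2780 cells (Homo sapiens) for antiproliferative activity, read by fluorescence, with a stated time of 72 h; a higher number here means a weaker inhibitor, a lower number a stronger inhibitor. For compound 1, > 10000 nM is a limit of the assay and not a number. Of the two numeric values, compound 2 at 140 nM has the lower number. Compound 3 at 410 nM stands higher, by more than the usual scatter, so compound 2 is the stronger inhibitor of these two.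

Compound 4 `CN1CCC(C(=O)N2Cc3c(NC(=O)c4ccc(C(F)(F)F)cc4)n[nH]c3C2(C)C)CC1` has not yet been measured. It differs from compound 2 in one place, with 4-(trifluoromethyl)phenyl in place of thiophen-3-yl on a carbonyl carbon.

Going by the values given here, no measured pair isolates this change, so the expectation rests on indirect ground. Compound 3 carries neither of these groups on its amide carbonyl and still gives 410 nM, which suggests that a change at this carbonyl need not abolish activity. A modest step toward a higher number is expected in this assay, probably a little beyond the scatter. The estimated step runs a 2.1-fold higher number from compound 2 to compound 4 (0.33 log units; beyond the scatter). For compound 4 the expected value is 300 nM, with an estimated range of 80 nM to 1200 nM.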

Compound 4, half-maximal inhibitory concentration: 60 nM
Estimate against measurement, compound 4: 5.0-fold (0.70 log units) above; measured number outside the range, below it.
By their numbers in this assay, from the lowest: compound 4; then compound 2; then compound 3. At a limit, above all of these: compound 1.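

The one-place change on the carbonyl carbon whose other neighbour is an amide-type nitrogen, 4-(trifluoromethyl)phenyl in place of thiophen-3-yl, gives in this assay a 2.3-fold lower number from compound 2 to compound 4 (0.37 log units; beyond the scatter), a modest step. Going by these compounds alone, this pair shows for the first time what the group at this position does with the rest of the structure held fixed, and the number moves by more than the usual scatter. The position accepts the larger six-membered aromatic ring of carbon only, and compound 4 shows that the sulfur of thiophen-3-yl is not required for activity in this range.

On these data alone, whether the lower number goes with the ring, with the trifluoromethyl group or with both stays open, and a plain phenyl group, or a phenyl group carrying a nitrile, a carboxylic acid or an amine in place of trifluoromethyl, would separate these readings. The data shown give no reason for the direction of this step.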